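A few compounds are considered here, and "the series" means these few. Any claim that something is new, unique, unknown or untested is made for them only; others in the source may bear on it.

Compounds measured in the paw edema test:

Compound 1 `CCCNC(=O)CC1CCc2cc(OC)c(OC)cc21` gives 28%.
Compound 2 `CCCCNC(=O)CC1CCc2cc(OC)c(OC)cc21` gives 24%.
Compound 3 `COc1cc2c(cc1OC)C(CC(=O)N1CCCCC1)CC2` gives 22%.

In a functional assay on the whole organism (strain Wistar) for inhibition, with Rattus norvegicus as the target, read by paw edema, with stated times of 60 min and 2 h, at a dose of 100 mg/kg by the oral route (a lower number here means less inhibition, a higher number more inhibition at the dose given (going by the name of the read-out)), the three numbers sit close together. Compound 2 stands second highest of the three, but its nearest neighbour is compound 3 with a number 2 percentage points lower from compound 2 to compound 3 (within the scatter), and its furthest is compound 1 with a number 4 percentage points lower from compound 1 to compound 2 (within the scatter), so none of these steps separates two compounds from one another.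

Compound 4 `COc1cc2c(cc1OC)C(CC(=O)N1CCOCC1)CC2` has not yet been measured. It differs from compound 2 by morpholin-4-yl in place of butylamino on a carbonyl carbon. Among the compounds with values here, the steps that bear on this are those where the open-chain amine on the carbonyl carbon was exchanged for a ring: a number 2 percentage points lower from compound 2 to compound 3 (within the scatter) and a number 6 percentage points lower from compound 1 to compound 3 (within the scatter). Both are within the scatter. Within the data shown here, nothing among the measured compounds speaks to the extra oxygen in the ring. The step is therefore expected to be a number 2 percentage points lower from compound 2 to compound 4 (within the scatter), with no change beyond the scatter. Compound 4 is estimated at 22%, in the range from 12% to 32%.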

Compound 4, a percentage reported as inhibition, in the whole organism at one dose (the size of the read-out at that dose, not a potency): 14%
Compound 4: the middle estimate sits 8 percentage points above what was measured; measured number inside the range.
By their numbers in this assay, from the lowest: compounds 4, 3, 2 and 1 (each within the scatter of the next, the first and the last beyond it).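

Within the data shown here, the exchange for morpholin-4-yl gives the first step to clear the usual scatter in this assay: a number 14 percentage points lower from compound 1 to compound 4 (beyond the scatter). Among these compounds, the two closer comparisons stay inside the scatter, a number 10 percentage points lower from compound 2 to compound 4 (within the scatter) and a number 8 percentage points lower from compound 3 to compound 4 (within the scatter), so the added ring oxygen, the only difference between compound 3 and compound 4, cannot be told apart from repeat-to-repeat variation, and only the comparison with the propylamino amide shows a real gap. No supporting data are available to explain that gap.

As far as these compounds go, it remains open whether another ring on the carbonyl carbon, such as piperazin-1-yl or thiomorpholin-4-yl, would give a number like that of compound 4 or like that of compound 1. A shorter open chain such as ethylamino also remains untested among the compounds shown.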